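The source may report more compounds than this note shows. Statements on the series, on what has been measured and on what is new or still open speak of the compounds shown alone.

Measured so far in a functional assay on NCI/ADR-RES cells (Homo sapiens) for inhibition; a higher number here means a weaker inhibitor of growth, a lower number a stronger inhibitor of growth:
- compound 1 `CN(C)c1ccc(NS(=O)(=O)c2c(F)c(F)c(F)c(F)c2F)cc1`: 96 nM
- compound 2 `Cc1ccc(NS(=O)(=O)c2c(F)c(F)c(F)c(F)c2F)cc1C`: 320 nM
- compound 3 `O=S(=O)(Nc1ccc2c(c1)OCCO2)c1c(F)c(F)c(F)c(F)c1F`: 410 nM

Compound 1 has the lowest number of the three, and compound 2 and compound 3 both lie above it, beyond the usual scatter. The next compound, compound 4 `COc1ccc(NS(=O)(=O)c2c(F)c(F)c(F)c(F)c2F)cc1`, keeps the core of compound 1 and changes one group: methoxy in place of dimethylamino on an aromatic carbon. This places methoxy in place of dimethylamino on an aromatic carbon, para to a large group. Within the data shown here, no measured pair isolates this change, so the expectation rests only on the three values. Compound 1 at 96 nM marks the low end, and compound 2 at 320 nM is its nearest neighbour. A moderate upward step in this assay is therefore expected, though a result within the scatter remains possible. The estimated step is a 2.3-fold higher number from compound 1 to compound 4 (0.36 log units; beyond the scatter). For compound 4 the estimated value is 220 nM, with an expected range of 90 nM to 500 nM.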

Compound 4, concentration for 50% growth inhibition: 58 nM
Compound 4: middle estimate off by 3.8-fold (0.58 log units), on the high side, outside the stated range (below it).
By their numbers in this assay, from the lowest: compounds 4 and 1 (each within the scatter of the next); then compounds 2 and 3 (each within the scatter of the next).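

In this assay, among these compounds, the exchange of dimethylamino for methoxy on an aromatic carbon, para to a large group, gives the first single-place comparison (a 1.7-fold lower number from compound 1 to compound 4 (0.22 log units; within the scatter)). At this position the two groups cannot be told apart, so dimethylamino is not needed for a value as low as that of compound 1, and an oxygen-linked methyl group serves equally well there. No measurement available here bears on the reason for this outcome.

Going by these compounds, this rests on one pair, so it remains open whether the position accepts other groups, such as a hydroxyl, a primary amine, a chlorine or a longer alkoxy chain, with values that stay close to those of compound 1 and compound 4. Also open, on these data alone, is whether the same exchange gives a similar step when the rest of the shared core is changed.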